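The source may report more compounds than this note shows. Statements on the series, on what has been measured and on what is new or still open speak of the compounds shown alone.

In a functional assay on HepG2 cells (Homo sapiens) for cytotoxicity, read by MTT assay, with a stated time of 72 h (on this read-out higher numbers stand for weaker inhibition and lower numbers for stronger inhibition), compound 3 `COc1ccc(CN2CCC(NC(=O)C(C)(C)Oc3ccc4c(=O)cc(-c5ccccc5)oc4c3)CC2)cc1` gives 8700 nM. Compound 1 `O=C(COc1ccc(-c2cc(=O)c3ccccc3o2)cc1)NC1CCN(Cc2ccccc2)CC1` in this assay gives 15500 nM, and the gap between compound 3 and compound 1 lies within the usual scatter, so neither can be set above the other. For the measured compounds named here, compound 2 `O=C(COc1ccc2c(=O)c(-c3ccccc3)coc2c1)N1CCN(Cc2ccccc2)CC1` in this assay reaches only a limit of > 20000 nM, which is not a number; this is the one value in the set that sits at the limit of > 20000 nM in this assay, at which 1 of the 3 values shown sits. Going by the values given here, no pair of these three compounds differs in a single place, so no measured step is available.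

Compound 4 `CC(C)(Oc1ccc2c(=O)cc(-c3ccccc3)oc2c1)C(=O)NC1CCN(Cc2ccc(C(F)(F)F)cc2)CC1` has not yet been tested in this assay. It differs from compound 3 by trifluoromethyl in place of methoxy on an aromatic carbon of the benzyl group. Among the compounds with values here, with no measured step of this kind among the three compounds, and with all numbers in this assay lying close together, the step from compound 3 to compound 4 is expected to stay small, and none beyond the scatter can be predicted with confidence; the expected step is a 1.2-fold lower number from compound 3 to compound 4 (0.09 log units; within the scatter). Compound 4 is therefore estimated to give about 7000 nM in this assay, with a likely range from 2500 nM to 20000 nM.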

Compound 4, half-maximal inhibitory concentration: > 20000 nM
Compound 4: only a limit was reported (the forecaster's own chance of this, stated with the estimate: 15%); middle value at least 2.8-fold (0.45 log units) from the limit.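

Trifluoromethyl in place of methoxy gives the first step in this set that changes one place only, and in this assay it reads as an at least 2.2-fold higher number from compound 3 to compound 4 (0.36 log units; beyond the scatter). For the compounds shown here, this shows that the group on the benzyl ring is not indifferent in this assay, something the earlier compounds, with no pair differing in a single place, could not show. The result for compound 4 is a limit and not a number, and it is the second such result in the set: the limit of > 20000 nM in this assay, at which 2 of the 4 values shown sit.

The compounds shown leave open whether the step reflects something methoxy contributes or something trifluoromethyl takes away, and how a hydrogen, a chlorine, a hydroxyl or an amine at this place would read in this assay. They also leave open whether the same exchange would give a step of this kind on the cores of compound 1 and compound 2, or whether it holds only on the core shared by compound 3 and compound 4.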